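The source may hold more compounds than are shown below. What is called first, only, known or untested is meant among the compounds shown, and "the series" means these compounds.

Compound 3 `COc1ccc(C(=O)/C=C/c2ccc(OCc3cn(Cc4ccccc4)nn3)cc2)cc1` stands highest of the three compounds measured in a functional assay on MCF7 cells (Homo sapiens) for inhibition, read by MTT assay, with a stated time of 48 h, tested at 10 uM (on this read-out higher numbers stand for more inhibition of growth at the one concentration tested and lower numbers for less inhibition of growth), where compound 3 gives 70%. Compound 2 `O=C(/C=C/c1ccc(OCc2cn(Cc3ccccc3Br)nn2)cc1)c1ccc(Br)cc1` gives 44%, and compound 1 `O=C(/C=C/c1ccc(OCc2cn(Cc3ccccc3)nn2)cc1)c1ccc(Br)cc1` gives 34%; the step of a number 36 percentage points higher from compound 1 to compound 3 (beyond the scatter) is the larger of the two measured steps. Compound 4 `COc1ccc(C(=O)/C=C/c2ccc(OCc3cn(Cc4ccccc4Br)nn3)cc2)cc1` differs from compound 3 by a single change: bromo in place of hydrogen on an aromatic carbon. The same change has been seen once before, in the step of a number 10 percentage points higher from compound 1 to compound 2 (within the scatter), which stayed within the scatter. A step of similar size is therefore expected here, so that a number 5 percentage points higher from compound 3 to compound 4 (within the scatter) is expected to remain within the scatter. On that basis compound 4 is estimated at 75%, with a range from 55% to 90%.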

Compound 4, percent growth inhibition at one concentration: 60%
Compound 4: the middle estimate sits 15 percentage points above what was measured; measured number inside the range.
By their numbers in this assay, from the lowest: compounds 1 and 2 (each within the scatter of the next); then compounds 4 and 3 (each within the scatter of the next).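

In this assay, 2-bromobenzyl in place of benzyl on the methoxy compounds reads as a number 10 percentage points lower from compound 3 to compound 4 (within the scatter). Neither bromo step leaves the scatter alone, yet taken together they show that this change does not act alike on both cores: the same change on two cores in this assay, a number 10 percentage points higher (within the scatter) from compound 1 to compound 2 and a number 10 percentage points lower (within the scatter) from compound 3 to compound 4, 20 percentage points apart, beyond the scatter of two such steps Methoxy in place of bromo still raises the number with 2-bromobenzyl present, as a number 16 percentage points higher from compound 2 to compound 4 (beyond the scatter), but by a different amount than with benzyl: the same change on two cores in this assay, a number 36 percentage points higher (beyond the scatter) from compound 1 to compound 3 and a number 16 percentage points higher (beyond the scatter) from compound 2 to compound 4, 20 percentage points apart, beyond the scatter of two such steps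

Still open, as far as these compounds go, is what an amine or a carboxylic acid in place of the bromo would give. A single concentration also leaves open how these compounds compare at other concentrations.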